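The source may hold more compounds than are shown below. What is called first, only, known or untested is meant among the compounds shown, and "the series" means these compounds.

Measured so far in a functional assay on MCF7 cells (Homo sapiens) for antiproliferative activity, read by MTT assay, with a stated time of 72 h; on this read-out higher numbers stand for weaker inhibition and lower numbers for stronger inhibition: compound 1 `COc1cc2c(Nc3ccc(C#N)cc3)ncnc2cc1OCCCN1CCCCC1` gives 35100 nM; compound 2 `COc1cc2c(Nc3ccc(C#N)cc3)ncnc2cc1OCCCN1CCC(C)CC1` gives 43100 nM; compound 3 `COc1cc2c(Nc3ccc(C#N)cc3)ncnc2cc1OCCCN1CCC(CO)CC1` gives 35100 nM.

Compound 3 stands level with compound 1 at the digits shown; its nearest neighbour is compound 1, with no change at the digits printed from compound 1 to compound 3 (within the scatter), and its furthest is compound 2, with a 1.2-fold lower number from compound 2 to compound 3 (0.09 log units; within the scatter). The step to compound 4 `COc1cc2c(Nc3ccc(C#N)cc3)ncnc2cc1OCCCN1CCc2ccccc2C1` is 1,2,3,4-tetrahydroisoquinolin-2-yl in place of 4-(hydroxymethyl)piperidin-1-yl on a saturated chain carbon, three bonds along the chain from an oxygen on an aromatic ring. Going by the values given here, no measured step exchanges the whole ring. The steps that alter this ring, a 1.2-fold higher number from compound 1 to compound 2 (0.09 log units; within the scatter) and no change at the digits printed from compound 1 to compound 3 (within the scatter), both lay within the scatter, as did a 1.2-fold lower number from compound 2 to compound 3 (0.09 log units; within the scatter). On that basis the expected step in this assay is a 1.0-fold lower number from compound 3 to compound 4 (0.00 log units; within the scatter), nothing beyond the scatter and with no clear direction. Compound 4 is therefore estimated at 35000 nM, in the range 14000 nM to 90000 nM.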

Compound 4, half-maximal inhibitory concentration: > 100000 nM
Compound 4: no number, only a limit; the forecaster's own chance of this, stated with the estimate: 10%; middle value at least 2.8-fold (0.45 log units) away from the limit.
By their numbers in this assay, from the lowest: compounds 1, 3 and 2 (each within the scatter of the next). At a limit, above all of these: compound 4.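

In this assay, compound 4 gives no number, only a limit of the assay: (the limit of > 100000 nM in this assay, at which 1 of the 4 values shown sits). At this saturated chain carbon, 1,2,3,4-tetrahydroisoquinolin-2-yl gives an at least 2.8-fold higher number from compound 1 to compound 4 (0.45 log units; beyond the scatter) against piperidin-1-yl, an at least 2.3-fold higher number from compound 2 to compound 4 (0.36 log units; beyond the scatter) against 4-methylpiperidin-1-yl and an at least 2.8-fold higher number from compound 3 to compound 4 (0.45 log units; beyond the scatter) against 4-(hydroxymethyl)piperidin-1-yl. Changes on the piperidine ring had stayed within the scatter, so this position is now seen to respond, beyond the scatter, to an exchange of the whole ring.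

Going by these compounds, how far compound 4 lies past its limit stays open. Also open, on these data alone, is whether the fused benzene ring itself matters, which a 4-benzylpiperidin-1-yl or a morpholin-4-yl group at this place could help to separate.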